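A few compounds are considered here, and "the series" means these few. Any claim that something is new, unique, unknown or untested is made for them only; others in the source may bear on it.

Measured compounds:
- compound 1 `O=C(CCCCCCc1ccccc1)c1nc(Cl)co1` — 4 nM
- compound 2 `CSc1coc(C(=O)CCCCCCc2ccccc2)n1` — 29 nM

Both compounds were tested in an assay on isolated protein for inhibition of Fatty-acid amide hydrolase 1 (Rattus norvegicus); on this read-out higher numbers stand for weaker inhibition and lower numbers for stronger inhibition. Compound 2 gives the higher of the two numbers, and its nearest neighbour is compound 1, measured at 4 nM; the difference, a 7.3-fold higher number from compound 1 to compound 2 (0.86 log units; beyond the scatter), lies beyond the scatter. Compound 3 `O=Cc1coc(C(=O)CCCCCCc2ccccc2)n1` keeps the shared core and the long chain ending in a phenyl ring, and differs from compound 2 only by formyl in place of methylsulfanyl on an aromatic carbon. Going by the values given here, no measured step shows a formyl group at this position, so the only guide is the step from chloro to methylsulfanyl, which shows that swapping the small group on this ring carbon shifts the read-out by a modest, clearly resolved amount. The size and direction of the move for compound 3 in this assay can therefore not be fixed from the data; an estimate a 2.9-fold lower number from compound 2 to compound 3 (0.46 log units; beyond the scatter) is expected to carry a wide range, putting compound 3 at 10 nM (range 2 nM to 50 nM).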

Compound 3, inhibition constant: 55 nM
Estimate against measurement, compound 3: 5.5-fold (0.74 log units) below; the measured number lies above the stated range.
By their numbers in this assay, from the lowest: compound 1; then compounds 2 and 3 (each within the scatter of the next).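

In this assay, formyl in place of methylsulfanyl on this aromatic carbon gives a 1.9-fold higher number from compound 2 to compound 3 (0.28 log units; within the scatter), so two groups with different atoms cannot be told apart here. Formyl in place of chloro gives a 14-fold higher number from compound 1 to compound 3 (1.14 log units; beyond the scatter), and as methylsulfanyl also stands clearly apart from chloro, chloro is now the one group of the three that gives a distinctly lower number, rather than just one point in a graded series. Nothing available here explains why chloro stands apart.

The compounds shown leave open whether this belongs to chloro alone or would also appear with bromo, methyl, a nitrile, an amine or a carboxylic acid on the same carbon. They also leave open whether the gap between these groups would hold with a shorter chain leading to the phenyl ring.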